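A few compounds are considered here, and "the series" means these few. Any claim that something is new, unique, unknown or untested is made for them only; others in the source may bear on it.

The series shares one core, differing only in the amine on the aniline ring. Compound 1 `CCC(=O)Nc1cccc(Oc2nc(Nc3ccc(N4CCN(C)CC4)cc3)ncc2Cl)c1` carries a 4-methylpiperazin-1-yl group and, in an assay on isolated protein for inhibition of NUAK family SNF1-like kinase 1 (Homo sapiens), read by ADP-Glo, with a stated time of 60 min, tested at 10 uM, in the presence of a further agent that is not named here (a lower number here means less inhibition, a higher number more inhibition at the concentration tested (going by the name of the read-out)), compound 1 gives 92.9%. Compound 2 `CCC(=O)Nc1cccc(Oc2nc(Nc3ccc(N(CC)CC)cc3)ncc2Cl)c1` carries diethylamino, and in this assay compound 2 gives 54.4%; the step of a number 38.5 percentage points lower from compound 1 to compound 2 (beyond the scatter) shows how strongly this position responds to a change of amine. Compound 3 `CCC(=O)Nc1cccc(Oc2nc(Nc3ccc(N4CCCC4)cc3)ncc2Cl)c1` carries pyrrolidin-1-yl; in this assay compound 3 is recorded as "not active" (no number reported), with no number given, so it stands at the bottom of the set without a value to quote.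

Compound 4 `CCC(=O)Nc1cccc(Oc2nc(Nc3ccc(N4CCC(C)CC4)cc3)ncc2Cl)c1` is the next step from compound 3: 4-methylpiperidin-1-yl in place of pyrrolidin-1-yl on an aromatic carbon. Going by the values given here, no measured pair describes this exact change. Among the compounds with values here, the only step that bears on it is a number 38.5 percentage points lower from compound 1 to compound 2 (beyond the scatter), which was large and downward when the 4-methylpiperazin-1-yl group was exchanged for an acyclic amine; compound 3, with its five-membered ring, gave nothing measurable. On that basis a modest rise from compound 3, if any, is expected in this assay, with a real chance that compound 4 again yields no number. Compound 4 is therefore estimated at 25%, within 0% to 60%.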

Compound 4, a percentage reported as inhibition, at one concentration (the size of the read-out at that concentration, not a potency): 13.4%
Estimate against measurement, compound 4: 11.6 percentage points above; the range from low to high includes it.
By their numbers in this assay, from the lowest: compound 4; then compound 2; then compound 1.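

Keeping a six-membered ring with its 4-methyl group is not enough to hold the response in this assay here: 4-methylpiperidin-1-yl in place of 4-methylpiperazin-1-yl gives a number 79.5 percentage points lower from compound 1 to compound 4 (beyond the scatter) and this is the largest step seen so far at this position. Going by these compounds alone, a ring as such does not favour the response over an open chain either, for 4-methylpiperidin-1-yl in place of diethylamino gives a number 41 percentage points lower from compound 2 to compound 4 (beyond the scatter) and compound 1 remains the only ring compound with a high value, so the identity of the ring matters more than its presence. No measurement shown here explains why these exchanges lower the response so sharply.

As far as these compounds go, the step from compound 3 to compound 4 cannot be read, compound 3 having no number, so the effect of going from pyrrolidin-1-yl to 4-methylpiperidin-1-yl remains unknown. The compounds shown also leave open whether the high value of compound 1 depends on the second ring nitrogen, its methyl group or both, which morpholin-4-yl or an unsubstituted piperazin-1-yl at the same place could help to separate.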